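This account rests on a few compounds, and the source may have more. Where it says the series, first, only, none or still open, it means among the compounds named here.

Working notes on the series in a functional assay on Huh-5-2 cells (Homo sapiens), read by MTT assay; a lower number here means that less compound is tolerated, a higher number that more compound is tolerated: compound 1 `CC(=O)c1ccc(-c2ccc(Cl)cc2)c(COc2ccc(-c3nc4cc(C(=O)O)ccc4n3C3CCCCC3)cc2)c1` gives 24000 nM, compound 2 `CN(C)c1ccc(-c2ccc(Cl)cc2)c(COc2ccc(-c3nc4cc(C(=O)O)ccc4n3C3CCCCC3)cc2)c1` gives 30000 nM, and compound 3 `N#Cc1ccc(-c2ccc(Cl)cc2)c(COc2ccc(-c3nc4cc(C(=O)O)ccc4n3C3CCCCC3)cc2)c1` gives 23000 nM. Compound 3 stands level with both others, since a 1.0-fold lower number from compound 1 to compound 3 (0.02 log units; within the scatter) and a 1.3-fold lower number from compound 2 to compound 3 (0.12 log units; within the scatter) both lie within the scatter, as does a 1.3-fold higher number from compound 1 to compound 2 (0.10 log units; within the scatter).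

Compound 4 `O=C(O)c1ccc2c(c1)nc(-c1ccc(OCc3cc(C(=O)NCc4ccccc4)ccc3-c3ccc(Cl)cc3)cc1)n2C1CCCCC1` carries benzylcarbamoyl in place of cyano on an aromatic carbon, para to a 4-chlorophenyl group: benzylcarbamoyl in place of cyano on an aromatic carbon. These three measured steps bear on the change, but none of them brings in an added ring, so the precedent is only partial. No step beyond the scatter is expected in this assay, in either direction. The estimated step is a 1.2-fold lower number from compound 3 to compound 4 (0.06 log units; within the scatter). For compound 4 the expected value is 20000 nM, with an estimated range of 10000 nM to 45000 nM.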

Compound 4, half-maximal cytotoxic concentration: 22000 nM
Compound 4: the middle estimate sits 1.1-fold (0.04 log units) below what was measured, and the stated range covers the measured number.
By their numbers in this assay, from the lowest: compounds 4, 3, 1 and 2 (each within the scatter of the next).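

In this assay, benzylcarbamoyl on this aromatic carbon adds a six-membered aromatic ring and a hydrogen-bond donor, yet all three new steps lie within the scatter (a 1.0-fold lower number from compound 3 to compound 4 (0.02 log units; within the scatter); a 1.4-fold lower number from compound 2 to compound 4 (0.13 log units; within the scatter); a 1.1-fold lower number from compound 1 to compound 4 (0.04 log units; within the scatter)). The position para to a 4-chlorophenyl group therefore takes this much larger group with the numbers still level, which the smaller acetyl, dimethylamino and cyano groups could not show. Nothing available explains this level behaviour.

From the compounds shown here alone, whether a carboxylic acid or a primary amine on this carbon would also stay level remains open.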